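Changing the link between compound 2 and compound 3

The source may report more compounds than this note shows. Statements on the series, on what has been measured and on what is new or still open speak of the compounds shown alone.

Measured so far:
compound 1, `COc1cc(Cl)cc(-c2nn(-c3cccc(NC(=O)Nc4ccc(Cl)c(Cl)c4)c3)cc2-c2ccncc2)c1`: 96%
compound 2, `COc1cc(Cl)cc(-c2nn(-c3cccc(NC(=O)Nc4cccc(C(F)(F)F)c4)c3)cc2-c2ccncc2)c1`: 98%

Of the compounds shown here, two have been measured in a functional assay on SK-MEL-5 cells (Homo sapiens) for inhibition, read by sulforhodamine B assay, with a stated time of 48 h, tested at 0.1 uM; a lower number here means a stronger effect, a higher number a weaker effect of the compound at the concentration tested. Compound 1 gives 96% in this assay, and compound 2 gives 98%. Of the two numbers, compound 2 has the larger one, but the step of a number 2 percentage points higher from compound 1 to compound 2 (within the scatter) is within the scatter, so the two compounds cannot be told apart on these figures; both leave cell growth almost untouched at this concentration.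

Compound 3 `COc1cc(Cl)cc(-c2nn(-c3cccc(NC(=O)c4cccc(C(F)(F)F)c4)c3)cc2-c2ccncc2)c1` differs from compound 2 in one place: 3-(trifluoromethyl)phenyl in place of (3-(trifluoromethyl)phenyl)amino on a carbonyl carbon. Among the compounds with values here, the only measured step, from compound 1 to compound 2, swaps the aryl group on the amide-type nitrogen and leaves the carbonyl link as it is, so no measured step bears directly on the change from compound 2 to compound 3. That one step was small, a number 2 percentage points higher from compound 1 to compound 2 (within the scatter), and there is nothing in the data to point toward a stronger effect for compound 3. The expected step is therefore none beyond the scatter, a number 3 percentage points lower from compound 2 to compound 3 (within the scatter). Compound 3 is estimated at 95% in this assay, within a range from 80% to 106%.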

Compound 3, a percentage reported as activity, at one concentration (the size of the read-out at that concentration, not a potency): 95%
Compound 3: middle estimate and measured number agree at the digits printed, within the range that was stated.
By their numbers in this assay, from the lowest: compounds 3, 1 and 2 (each within the scatter of the next).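

Within the data shown here, the change gives a number 3 percentage points lower from compound 2 to compound 3 (within the scatter) in this assay, the first reading at the carbonyl carbon itself, since the earlier step altered only the aryl group on the amide-type nitrogen. With 3-(trifluoromethyl)phenyl placed directly on that carbon in place of (3-(trifluoromethyl)phenyl)amino, the two compounds cannot be told apart at this concentration, so here the amino nitrogen of the link is not needed to keep the number where it stands. The comparison with the dichlorinated compound, a number 1 percentage points lower from compound 1 to compound 3 (within the scatter), reads the same way, and no measurement of any property of these compounds is available to account for the result.

It remains open whether any group on this carbonyl carbon can move the number beyond the scatter, for example a piperazine or a simple alkyl amine in place of the aryl-bearing groups shown. The three compounds also leave open whether the change from the amino link to the direct link would matter at a concentration where these compounds have a clear effect on the cells.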